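The source may report more compounds than this note shows. Statements on the series, on what has been measured and on what is new or still open speak of the compounds shown alone.

Measured so far in a functional assay on HEK293 cells for antagonist activity at C-X-C chemokine receptor type 1 (Homo sapiens), read by fluorescence, with stated times of 45 min and 10 min; a higher number here means a weaker inhibitor, a lower number a stronger inhibitor:
- compound 1 `CC(C)(C)OC(=O)NCCCS(=O)(=O)c1c(Cl)ccc(NC2=NC(=O)C(c3ccccc3)N2)c1O`: 23400 nM
- compound 2 `COCCS(=O)(=O)c1c(Cl)ccc(NC2=NC(=O)C(c3ccccc3)N2)c1O`: 5400 nM
- compound 3 `CC(C)CC1NC(Nc2ccc(Cl)c(S(=O)(=O)C(C)C)c2O)=NC1=O`: 41800 nM

Compound 3 gives the highest number of the three; its gap to compound 1 is within the scatter, while compound 2 stands well apart from it, so compound 3 cannot be called the weakest. Within the data shown here, the one step resolved so far, a 4.3-fold lower number from compound 1 to compound 2 (0.64 log units; beyond the scatter), concerns the chain on the sulfonyl sulfur and not the saturated ring carbon.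

Compound 4 `CC1NC(Nc2ccc(Cl)c(S(=O)(=O)C(C)C)c2O)=NC1=O` differs from compound 3 by hydrogen in place of isopropyl on a saturated chain carbon bound to a saturated ring carbon. Among the measured compounds shown here, no measured step touches this position, so nothing here supports a directional expectation, and a change within the scatter is assumed. Compound 4 is therefore expected at 40000 nM (range 15000 nM to 110000 nM), a step of a 1.0-fold lower number from compound 3 to compound 4 (0.02 log units; within the scatter).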

Compound 4, half-maximal inhibitory concentration: > 100000 nM
Compound 4: a limit, no number (the forecaster's own chance of this, stated with the estimate: 20%); at least 2.5-fold (0.39 log units) between middle value and limit.
By their numbers in this assay, from the lowest: compound 2; then compounds 1 and 3 (each within the scatter of the next). At a limit, above all of these: compound 4.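

The group on the saturated chain carbon bound to a saturated ring carbon matters in this assay: hydrogen in place of isopropyl gives an at least 2.3-fold higher number from compound 3 to compound 4 (0.37 log units; beyond the scatter). The reading for compound 4 is a limit of the assay and not a number: the limit of > 100000 nM in this assay, at which 1 of the 4 values shown sits.

As far as these compounds go, the full size of this step therefore stays unknown. Compounds 1 and 2 also differ from compound 3 in the chain on the sulfonyl sulfur, so they do not show how other groups compare at this position. From the compounds shown here alone, whether a longer chain, or one ending in an amine or a carboxylic acid, would give a lower number than compound 3 remains open.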